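The compounds below may be only part of what the source reports. "The series", "measured", "known", "first", "only" and "open" are said of these compounds alone.

Of the compounds shown here, two share one core and have been tested in a functional assay on SK-LU-1 cells (Homo sapiens) for cytotoxicity, read by sulforhodamine B assay, with a stated time of 48 h, tested at 50 uM; a lower number here means less inhibition, a higher number more inhibition at the concentration tested (going by the name of the read-out). Among the measured compounds shown here, compound 2, with the structure `Nc1nccc(-c2cnc3ccccc3c2)n1`, carries a free amino group on its core; in this assay compound 2 gives 59.3%, the higher of the two numbers measured so far. Compound 1, with the structure `FC(F)(F)c1ccc(Nc2nccc(-c3cnc4ccccc4c3)n2)cc1`, carries a 4-(trifluoromethyl)phenyl group on that same nitrogen; in this assay compound 1 gives 35.4%, a value that lies beyond the usual scatter below that of compound 2.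

Compound 3, with the structure `Cc1ccc(Nc2nccc(-c3cnc4ccccc4c3)n2)cc1`, has not yet been tested. It differs from compound 2 in one place: 4-methylphenyl in place of hydrogen on a nitrogen on an aromatic ring. For the measured compounds named here, in the one comparison available, the amine that carries a substituted phenyl group on its nitrogen, compound 1, sits well below compound 2. On that basis the step from compound 2 to compound 3 is expected to be a drop of a number 19.3 percentage points lower from compound 2 to compound 3 (beyond the scatter), beyond the scatter. Compound 3 is therefore expected to give about 40% in this assay, with a likely range from 25% to 58%.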

Compound 3, a percentage reported as inhibition, at one concentration (the size of the read-out at that concentration, not a potency): 46.3%
Estimate against measurement, compound 3: 6.3 percentage points below; low and high end bracket the measured number.
By their numbers in this assay, from the lowest: compound 1; then compound 3; then compound 2.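

In this assay, among the compounds shown here, placing 4-methylphenyl on the nitrogen in place of hydrogen gives a number 13 percentage points lower from compound 2 to compound 3 (beyond the scatter), so compound 1 is no longer the only compound with a substituted phenyl group on this nitrogen to read lower than the free amine of compound 2. For the compounds shown here, the new compound also allows the first comparison of two groups on that phenyl ring: methyl in place of trifluoromethyl on an aromatic carbon gives a number 10.9 percentage points higher from compound 1 to compound 3 (beyond the scatter), which shows that the number depends on what the ring carries and not only on the presence of the ring. Nothing available explains either step.

Going by these compounds, with only methyl and trifluoromethyl compared, and both on the same ring carbon, it remains open how a methoxy group, a chlorine atom or a carboxylic acid at that place would read in this assay. On these data alone, it is also open whether a group without an aromatic ring, such as a cyclohexyl group or a short alkyl chain on the same nitrogen, would lower the number as well, or whether the drop belongs to the phenyl groups.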